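Swapping trifluoromethyl for bromo in a cytotoxicity series

The compounds below may be only part of what the source reports. "The series", "measured", "known", "first", "only" and "open" are said of these compounds alone.

Measured compounds:
compound 1, `OC(c1ccc(Cl)cc1)(c1cccnc1)c1ccccc1Br`, 55200 nM
compound 2, `OC(c1ccc(Cl)cc1)(c1cccnc1)c1ccccc1C(F)(F)F`, 59300 nM
compound 3, `OC(c1ccc(Cl)cc1)(c1cccnc1)c1ccc(C(F)(F)F)cc1F`, 57400 nM

Of the compounds shown here, three have been tested in an ADME assay on L6 cells (Rattus norvegicus) for cytotoxicity, read by resazurin assay, with a stated time of 72 h; on this read-out higher numbers stand for weaker inhibition and lower numbers for stronger inhibition. Compound 1 gives 55200 nM, compound 2 gives 59300 nM and compound 3 gives 57400 nM, all three numbers lying close together. Compound 1 differs from compound 2 in one place, (bromo in place of trifluoromethyl on an aromatic carbon), and that change made a 1.1-fold lower number from compound 2 to compound 1 (0.03 log units; within the scatter). Compound 3 and compound 2 share a core whose difference is not broken down here. Compound 4, `OC(c1ccc(Cl)cc1)(c1cccnc1)c1ccc(Br)cc1F`, is not yet measured; it differs from compound 3 in one place, (bromo in place of trifluoromethyl on an aromatic carbon). For the measured compounds named here, this is the same kind of change as the one from compound 2 to compound 1, but the surroundings differ: in compound 1 the bromo sits ortho to a large group, whereas in compound 4 it sits meta to a fluoro group and para to a large group. Because the earlier step was a 1.1-fold lower number from compound 2 to compound 1 (0.03 log units; within the scatter), compound 4 is expected to show a step of about a 1.0-fold lower number from compound 3 to compound 4 (0.02 log units; within the scatter) in this assay. The estimate for compound 4 is 55000 nM, with a range from 30000 nM to 100000 nM.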

Compound 4, half-maximal inhibitory concentration: 79200 nM
Compound 4: middle estimate off by 1.4-fold (0.16 log units), on the low side, and the stated range covers the measured number.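

In this assay, putting bromo in place of trifluoromethyl on the second core gave a 1.4-fold higher number from compound 3 to compound 4 (0.14 log units; within the scatter), a step no larger than repeat measurements could produce. Set beside the earlier step, the same change shows no difference between the two cores that can be told apart: the same change on two cores in this assay, a 1.1-fold lower number (0.03 log units; within the scatter) from compound 2 to compound 1 and a 1.4-fold higher number (0.14 log units; within the scatter) from compound 3 to compound 4, 1.5-fold (0.17 log units) apart, within the scatter of two such steps This supports only a modest statement, that on these two cores the swap left the number within the scatter; it does not show that the change would behave alike on other cores or in other kinds of assay, and two pairs are too few to establish a rule for the series.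

At the changing place the compounds shown carry only bromo or trifluoromethyl, so it remains open whether an amine or a carboxylic acid there would shift the number beyond the scatter. As far as these compounds go, it also remains open whether the swap would stay this quiet on a third core.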